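The source may hold more compounds than are shown below. What is called first, only, known or untested is meant among the compounds shown, and "the series" means these compounds.

Of the compounds shown here, three sharing one core have been measured in a functional assay on the whole organism (blood, strain ICR) with Mus musculus as the target, in the glucose tolerance test, with a stated time of 30 min; a lower number here means that less compound is needed, a higher number that more compound is needed for the effect. Compound 1 `CN(C)C(=O)C1CCN(c2nc(-c3cc(F)c(Cl)cc3F)nc3c2CS(=O)(=O)C3)CC1` gives 1 mg/kg in this assay. Compound 2 `NC(=O)C1CCN(c2nc(-c3cc(F)c(Cl)cc3F)nc3c2CS(=O)(=O)C3)CC1`, with amino in place of dimethylamino on the carbonyl carbon, gives 3 mg/kg, and compound 3 `O=S1(=O)Cc2nc(-c3cc(F)c(Cl)cc3F)nc(N3CCC(O)CC3)c2C1`, which carries a hydroxy on the saturated ring carbon, gives 1 mg/kg. For the measured compounds named here, compound 3 thus stands level with compound 1 at the digits given and, together with it, at the lowest of the three numbers; the only step beyond the scatter is a 3.0-fold lower number from compound 2 to compound 3 (0.48 log units; beyond the scatter), while no change at the digits printed from compound 1 to compound 3 (within the scatter).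

Compound 4 `NC(=O)CCC1CCN(c2nc(-c3cc(F)c(Cl)cc3F)nc3c2CS(=O)(=O)C3)CC1` differs from compound 3 by 2-carbamoylethyl in place of hydroxy on a saturated ring carbon. Of the measured steps, the exchange of hydroxy for carbamoyl bears most directly: a 3.0-fold lower number from compound 2 to compound 3 (0.48 log units; beyond the scatter), so restoring a carbamoyl, now set on the 2-carbamoylethyl chain, points toward a modestly higher number. At the same time no change at the digits printed from compound 1 to compound 3 (within the scatter) shows that a large group on this carbon need not raise the dose. Compound 4 is therefore expected to give 2 mg/kg, with a range of 1 mg/kg to 6 mg/kg. The expected step is a 2.0-fold higher number from compound 3 to compound 4 (0.30 log units; within the scatter).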

Compound 4, minimum effective dose in the Mus musculus assay: 0.3 mg/kg
Estimate against measurement, compound 4: 6.7-fold (0.82 log units) above; measured number outside the range, below it.
By their numbers in the Mus musculus assay, from the lowest: compound 4; then compounds 1 and 3 (each within the scatter of the next); then compound 2.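

In the Mus musculus assay, the 2-carbamoylethyl chain on this saturated ring carbon gives the lowest number of the four compounds: a 3.3-fold lower number from compound 3 to compound 4 (0.52 log units; beyond the scatter), a 3.3-fold lower number from compound 1 to compound 4 (0.52 log units; beyond the scatter) and a 10-fold lower number from compound 2 to compound 4 (1.00 log units; beyond the scatter). A carbamoyl set directly on the ring carbon had given the highest number, whereas the same group carried on the 2-carbamoylethyl chain gives the lowest, so at this position the outcome depends on more than the presence of a carbamoyl. The change does not pay off everywhere: in a physicochemical assay for solubility, with a stated time of 20 h, at pH 6.8 (a lower number here means a less soluble compound, a higher number a more soluble compound), compound 3 gives 91000 nM and compound 4 gives 8000 nM, an 11-fold lower number from compound 3 to compound 4 (1.06 log units; beyond the scatter).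

Going by these compounds, it remains open whether the lower number follows from the chain or from its carbamoyl end, a question that a chain ending in a carboxylic acid or an amine could separate. Also open, on these data alone, is whether a longer chain would lower the number further, and how it would stand in the physicochemical assay.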